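Side-chain ester variation on the shared core

This account rests on a few compounds, and the source may have more. Where it says the series, first, only, none or still open, it means among the compounds named here.

Among the measured compounds shown here, compound 2 `CCCC(CC(=O)O[C@H](CC=C(C)C)C1=CC(=O)c2c(O)ccc(O)c2C1=O)OC(C)=O` gives 55700 nM in a functional assay on DU-145 cells (Homo sapiens) for cytotoxicity, read by MTT assay (a lower number here means a stronger inhibitor, a higher number a weaker inhibitor), the highest of the two numbers measured so far; the nearest is compound 1 `CC(=O)OCCO[C@H](CC=C(C)C)C1=CC(=O)c2c(O)ccc(O)c2C1=O`, which gives 15500 nM, a gap beyond the scatter. Compound 3 `CC(C)=CC[C@@H](OC(=O)CC(C)(O)c1ccccc1)C1=CC(=O)c2c(O)ccc(O)c2C1=O` is not yet measured. It differs from compound 2 by 1-hydroxy-1-phenylethyl in place of 1-acetoxybutyl on a saturated chain carbon bound to a carbonyl carbon. For the measured compounds named here, no step between measured compounds carries this change, so its size is open. The step of a 1.9-fold lower number from compound 2 to compound 3 (0.27 log units; within the scatter) is expected to be a modest move toward lower numbers, possibly no more than the scatter. Compound 3 is expected to give 30000 nM in this assay, within 8000 nM to 100000 nM.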

Compound 3, half-maximal inhibitory concentration: > 100000 nM
Compound 3 was reported as a limit; the forecaster's own chance of this, stated with the estimate: 10%; at least 3.3-fold (0.52 log units) between middle value and limit.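

In this assay compound 3 reads as a limit, not a number: the limit of > 100000 nM in this assay, at which 1 of the 3 values shown sits.

Putting 1-hydroxy-1-phenylethyl in place of 1-acetoxybutyl on a saturated chain carbon bound to a carbonyl carbon gives an at least 1.7-fold higher number from compound 2 to compound 3 (0.25 log units; that floor lies within the scatter), so this change brings no move toward lower numbers, though its true size remains unfixed. Among the compounds shown here, this is the first reading at this position to reach the assay's limit.

The hydroxyl and the phenyl ring enter together, so their separate shares cannot be told apart. From the compounds shown here alone, whether an amine or a carboxylic acid at this position would give a lower number remains open.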